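Varying the Aromatic Substituent on a Sulfonamide Scaffold

The source may report more compounds than this note shows. Statements on the series, on what has been measured and on what is new or still open speak of the compounds shown alone.

The three measured compounds share one core and differ only in the group carried on the aromatic ring. Compound 1 `CCCCN(C)c1cc(C(F)(F)F)ccc1CNC(=O)C(C)c1ccc(NS(C)(=O)=O)c(F)c1` gives 1.2 nM in an assay on CHO cells for antagonist activity at transient receptor potential cation channel subfamily V member 1 (Homo sapiens), read by FLIPR; on this read-out higher numbers stand for weaker inhibition and lower numbers for stronger inhibition. Compound 2 `CC(C(=O)NCc1ccc(C(F)(F)F)cc1N1CCCCCC1)c1ccc(NS(C)(=O)=O)c(F)c1` gives 1.6 nM in this assay, and compound 3 `CC(C(=O)NCc1ccc(C(F)(F)F)cc1SCc1ccco1)c1ccc(NS(C)(=O)=O)c(F)c1` gives 3.2 nM in this assay. Compound 3 thus stands at the highest number of the three, though one of the two gaps is a 2.0-fold higher number from compound 2 to compound 3 (0.30 log units; within the scatter), while the other is a 2.7-fold higher number from compound 1 to compound 3 (0.43 log units; beyond the scatter), a modest step.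

Compound 4 `CC(C(=O)NCc1ccc(C(F)(F)F)cc1-c1cccnc1)c1ccc(NS(C)(=O)=O)c(F)c1` follows from compound 3 by a single change: pyridin-3-yl in place of ((furan-2-yl)methyl)sulfanyl on an aromatic carbon.

Among the measured compounds shown here, the steps that bear on this change are the two that exchange the group at the same aromatic carbon, a 2.7-fold higher number from compound 1 to compound 3 (0.43 log units; beyond the scatter) and a 2.0-fold higher number from compound 2 to compound 3 (0.30 log units; within the scatter). Both show that the three quite different groups tried here all give numbers within a narrow band. For the measured compounds named here, a pyridin-3-yl substituent is a fourth variation at that position, and no measured step points to a larger effect than those already seen. The step to compound 4 is therefore expected to be small, with compound 4 estimated at 3 nM, its range from 1 nM to 10 nM in this assay. The expected step is a 1.1-fold lower number from compound 3 to compound 4 (0.03 log units; within the scatter).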

Compound 4, inhibition constant: 59.4 nM
Estimate against measurement, compound 4: 20-fold (1.30 log units) below; measured number above the stated range.
By their numbers in this assay, from the lowest: compounds 1, 2 and 3 (each within the scatter of the next, the first and the last beyond it); then compound 4.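

Among the compounds shown here, the position is less forgiving than the first three compounds suggested: in this assay the change gives a 19-fold higher number from compound 3 to compound 4 (1.27 log units; beyond the scatter), and the comparisons with the amines give a 37-fold higher number from compound 2 to compound 4 (1.57 log units; beyond the scatter) and a 50-fold higher number from compound 1 to compound 4 (1.69 log units; beyond the scatter), each much larger than any step among the earlier compounds. The result also shows that similar counts do not keep a compound in the earlier narrow band, since ((furan-2-yl)methyl)sulfanyl with 7 heavy atoms and pyridin-3-yl with 6 heavy atoms each bring one aromatic ring with 1 hetero atom, yet their numbers lie far apart; among the four compounds, only compound 4 has its ring bonded directly to the aromatic carbon, while compounds 1 and 2 connect through nitrogen and compound 3 through sulfur. Nothing given here explains the size of this step.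

The compounds shown leave open whether the direct ring bond or the pyridine nitrogen goes with the higher number, a question that a phenyl group at the same carbon would address. They also leave open whether a (pyridin-3-yl)methylsulfanyl group would return to the earlier band.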